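Replacing Methyl with 5-Methylthiophen-2-yl on the Carbonyl

A few compounds are considered here, and "the series" means these few. Any claim that something is new, unique, unknown or untested is made for them only; others in the source may bear on it.

Three compounds sharing one core were tested for cytotoxicity in an ADME assay on L929 cells (Mus musculus) for cytotoxicity, read by resazurin assay, with a stated time of 72 h; on this read-out higher numbers stand for weaker inhibition and lower numbers for stronger inhibition. Compound 1 `OB1OCc2ccc(-n3cc(Sc4ccc(Cl)c(Cl)c4)c4ccccc43)cc21` gives > 10 ug/mL, which is a limit of the assay rather than a number. Compound 2 `OB1OCc2ccc(-n3cccc3)cc21` gives > 10 ug/mL, again only a limit. Compound 3 `CC(=O)c1ccn(-c2ccc3c(c2)B(O)OC3)c1`, carrying acetyl in place of hydrogen on an aromatic carbon, gives > 10 ug/mL, once more a limit. Compound 3 thus stands at the same limit as the other two, and the step that the two limits leave unreadable from compound 2 to compound 3 cannot be read. All three values sit on one line: the limit of > 10 ug/mL in this assay, at which 3 of the 3 values shown sit. Compound 4 `Cc1ccc(C(=O)c2ccn(-c3ccc4c(c3)B(O)OC4)c2)s1` has not yet been measured; it differs from compound 3 by 5-methylthiophen-2-yl in place of methyl on a carbonyl carbon. Among the measured compounds shown here, no measured step involves a change on a carbonyl carbon, and the single recorded step is unreadable. The measurements offer no sign that compound 4 would leave the limit. The expected step is a step that the limit leaves unreadable from compound 3 to compound 4, within the scatter. Compound 4 is estimated at 15 ug/mL, with a range from 5 ug/mL to 50 ug/mL, and will most likely be reported as a limit again.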

Compound 4, half-maximal inhibitory concentration: > 10 ug/mL
Compound 4: only a limit was reported; the forecaster's own chance of this, stated with the estimate: 75%; the middle value lies beyond the limit too.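

Among the compounds shown here, compound 3 and compound 4 both give only a limit, so no step between them can be read, and the whole set stands the same way: the limit of > 10 ug/mL in this assay, at which 4 of the 4 values shown sit.

The compounds shown leave open where their true values lie in this assay and which change to the shared core, if any, would give a readable number.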